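Alkyne-linked aryl series: pyridin-3-yl analogue of compound 3

A few compounds are considered here, and "the series" means these few. Any claim that something is new, unique, unknown or untested is made for them only; others in the source may bear on it.

Measured compounds in a functional assay on isolated protein for antagonist activity at Orexin receptor type 2 (Homo sapiens), read by FLIPR and calcium flux; a lower number here means a stronger inhibitor, a higher number a weaker inhibitor:
compound 1, `Cc1ccc(-n2nccn2)c(C(=O)N2C[C@H](/C=C\c3ccc(F)cn3)CC[C@H]2C)c1`, gives 417 nM
compound 2, `Cc1ccc(-n2nccn2)c(C(=O)N2C[C@H](C#Cc3cncc(CO)c3)CC[C@H]2C)c1`, gives "not determined" (no result reported)
compound 3, `Cc1ccc(-n2nccn2)c(C(=O)N2C[C@H](C#Cc3ccc(F)cn3)CC[C@H]2C)c1`, gives 24 nM

Compound 3 carries the lowest number of the two that exist in this assay. Within the data shown here, its nearest neighbour is compound 1, and the only single-point step in the set, a 17-fold lower number from compound 1 to compound 3 (1.24 log units; beyond the scatter), is the move from the ethenyl to the ethynyl linker; that step is large and beyond the scatter. Compound 2 shares the ethynyl linker and the shared core of compound 3 but contributes no number.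

Compound 4, `Cc1ccc(-n2nccn2)c(C(=O)N2C[C@H](C#Cc3cccnc3)CC[C@H]2C)c1`, differs from compound 3 only in the aryl group at the end of the triple bond: pyridin-3-yl in place of 5-fluoropyridin-2-yl on a triple-bonded carbon. Among the measured compounds shown here, no measured step in the set changes the aryl group on the ethynyl linker, so nothing bears directly on this change; the one step in hand concerns the linker itself and is not transferable. The expectation for compound 4 is therefore a modest weakening at most, with a step of a 2.3-fold higher number from compound 3 to compound 4 (0.36 log units; beyond the scatter) that is expected to stay near the scatter. Compound 4 is estimated at 55 nM in this assay, with a range from 15 nM to 200 nM.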

Compound 4, half-maximal inhibitory concentration: 28 nM
Beside the measured number, compound 4's estimate is 2.0-fold (0.29 log units) above it, and the stated range covers the measured number.
By their numbers in this assay, from the lowest: compounds 3 and 4 (each within the scatter of the next); then compound 1.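

In this assay, a 1.2-fold higher number from compound 3 to compound 4 (0.07 log units; within the scatter), so at this place, on a triple-bonded carbon, 5-fluoropyridin-2-yl and pyridin-3-yl cannot be told apart, even though the exchange removes the fluorine and shifts the ring attachment from the 2-yl to the 3-yl form. Among these compounds, the large gap to the ethenyl compound also holds with this second aryl group, with a 15-fold lower number from compound 1 to compound 4 (1.17 log units; beyond the scatter); this step changes both the linker and the aryl group, but compound 3 and compound 4 both stand well clear of compound 1, and no compound with a number goes against this. No measured information is available to explain either the tolerance of the aryl exchange or the size of the gap to compound 1.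

Because the fluorine and the ring attachment change together here, their separate contributions remain unresolved, and a pyridin-2-yl or a 5-fluoropyridin-3-yl group would be needed to pull them apart. From the compounds shown here alone, it is also open whether this tolerance extends to a plain phenyl group, or to a pyridine ring bearing an amine or a carboxylic acid, at the end of the triple bond.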